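The source may report more compounds than this note shows. Statements on the series, on what has been measured and on what is new or still open speak of the compounds shown alone.

Measured so far in a functional assay on OVCAR-8 cells (Homo sapiens) for antiproliferative activity; on this read-out higher numbers stand for weaker inhibition and lower numbers for stronger inhibition:
- compound 1 `CNC(=O)C[C@@H]1C[C@@H](c2ccc(Cl)c(Cl)c2)[C@H](NC(=O)c2cc(-c3c(Cl)cnn3C)c(Cl)o2)CN1` gives 1130 nM
- compound 2 `Cn1ncc(Cl)c1-c1cc(C(=O)N[C@@H]2CN[C@H](CC(O)CO)C[C@H]2c2ccc(F)c(F)c2)oc1Cl` gives 690 nM
- compound 3 `Cn1ncc(Cl)c1-c1cc(C(=O)N[C@@H]2CN[C@H](CCN3CCC(O)CC3)C[C@H]2c2ccc(Cl)c(Cl)c2)oc1Cl` gives 15900 nM

Compound 3 has the highest number of the three, which makes it the weakest inhibitor here, and its gaps to compound 1 and compound 2 both lie beyond the scatter. Compound 4 `Cn1ncc(Cl)c1-c1cc(C(=O)N[C@@H]2CN[C@H](CCn3cncn3)C[C@H]2c2ccc(Cl)c(Cl)c2)oc1Cl` has not been measured yet. It differs from compound 3 in one place (1H-1,2,4-triazol-1-yl in place of 4-hydroxypiperidin-1-yl on a saturated chain carbon, two bonds along the chain from a saturated ring carbon), at the end of the same chain.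

Within the data shown here, the one measured step that bears on this change is a 14-fold higher number from compound 1 to compound 3 (1.15 log units; beyond the scatter), a large rise that came with (4-hydroxypiperidin-1-yl)methyl in place of methylcarbamoyl. Compound 4 gives up that same 4-hydroxypiperidin-1-yl group. Among the measured compounds shown here, no measured compound carries 1H-1,2,4-triazol-1-yl, so how much of the rise is recovered remains open, though most of it may be. The expected change, toward stronger inhibition, is a 6.4-fold lower number from compound 3 to compound 4 (0.80 log units; beyond the scatter) and would be large. Compound 4 is expected near 2500 nM, with an estimated range from 700 nM to 9000 nM.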

Compound 4, half-maximal inhibitory concentration: 1560 nM
For compound 4 the middle estimate is 1.6-fold (0.20 log units) above the measured one; low and high end bracket the measured number.
By their numbers in this assay, from the lowest: compounds 2, 1 and 4 (each within the scatter of the next, the first and the last beyond it); then compound 3.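

In this assay, putting 1H-1,2,4-triazol-1-yl in place of 4-hydroxypiperidin-1-yl at the end of the same chain gives a 10-fold lower number from compound 3 to compound 4 (1.01 log units; beyond the scatter), so the chain alone does not bring the weak inhibition of compound 3; it appears only with the 4-hydroxypiperidin-1-yl end group. The comparison with the shorter methylcarbamoyl side chain gives a 1.4-fold higher number from compound 1 to compound 4 (0.14 log units; within the scatter), which lies within the scatter, so this position accepts both an open-chain amide and an aromatic triazole without a difference that can be read. No measured property is available to explain why the two end groups on this chain differ so much.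

The compounds shown leave open which part of the 4-hydroxypiperidin-1-yl group goes with the weak inhibition: its hydroxyl, its ring nitrogen or its six-membered ring. A plain piperidin-1-yl, a morpholin-4-yl or a 1H-imidazol-1-yl on the same chain would help separate these possibilities.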